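The source may hold more compounds than are shown below. What is called first, only, known or untested is meant among the compounds shown, and "the series" means these compounds.

Working notes on the amine end of the series, read in a functional assay on MCF7 cells (Homo sapiens) for antiproliferative activity; a lower number here means a stronger inhibitor, a higher number a weaker inhibitor. Compound 1 (`CC(C)=CCc1cc(C(=O)Nc2cc3ccc(OCCCNC4CCCCC4)c(C)c3oc2=O)ccc1O`) gives 1070 nM. Among the compounds with values here, compound 3 (`CC(C)=CCc1cc(C(=O)Nc2cc3ccc(OCCCNCc4ccccc4)c(C)c3oc2=O)ccc1O`) gives 910 nM, which lies within the scatter of the only other number in the set. Compound 2 (`CC(C)=CCc1cc(C(=O)Nc2cc3ccc(OCCCN(C)c4ccccc4)c(C)c3oc2=O)ccc1O`) reads > 50000 nM, which is a limit of the assay and not a number.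

Compound 4 (`CC(C)=CCc1cc(C(=O)Nc2cc3ccc(OCCCN[C@@H]4C[C@H]5CC[C@@H]4C5)c(C)c3oc2=O)ccc1O`) carries a group with 2 five-membered non-aromatic rings of carbon only in place of benzyl, on an amine nitrogen: a group of 7 heavy atoms (7 carbon; 2 five-membered non-aromatic rings of carbon only) in place of a group of 7 heavy atoms (7 carbon; one six-membered aromatic ring of carbon only), on an amine nitrogen. The nearest measured change is the exchange of cyclohexyl for benzyl on an amine nitrogen, a 1.2-fold lower number from compound 1 to compound 3 (0.07 log units; within the scatter). The large steps of an at least 46-fold higher number from compound 1 to compound 2 (1.66 log units; beyond the scatter) and an at least 54-fold lower number from compound 2 to compound 3 (1.73 log units; beyond the scatter) both involve methyl(phenyl)amino, which is absent from compound 4, so they bear on it only weakly. Compound 1, with a non-aromatic ring at 1070 nM, therefore sets the expectation of no change beyond the scatter in this assay. The expected step is a 1.1-fold higher number from compound 3 to compound 4 (0.04 log units; within the scatter). Compound 4 is estimated at 1000 nM, with an expected range of 400 nM to 3000 nM.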

Compound 4, half-maximal inhibitory concentration: 1030 nM
Compound 4: middle estimate off by 1.0-fold (0.01 log units), on the low side; measured number inside the range.
By their numbers in this assay, from the lowest: compounds 3, 4 and 1 (each within the scatter of the next). At a limit, above all of these: compound 2.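

In this assay, the group with 2 five-membered non-aromatic rings of carbon only, carrying 3 defined stereocentres, gives no separation on the amine nitrogen from benzyl, a 1.1-fold higher number from compound 3 to compound 4 (0.05 log units; within the scatter), or from cyclohexyl, a 1.0-fold lower number from compound 1 to compound 4 (0.02 log units; within the scatter). Compounds 1, 3 and 4 thus show that this nitrogen accepts three different carbon-only groups, aromatic or not, without a step beyond the scatter, while compound 2 goes against this pattern, an at least 48-fold lower number from compound 2 to compound 4 (1.68 log units; beyond the scatter). The value of compound 2 is a limit and not a number: the limit of > 50000 nM in this assay, at which 1 of the 4 values shown sits.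

The compounds shown do not separate the methyl from the phenyl in methyl(phenyl)amino; a phenylamino or a methyl(benzyl)amino group would bear on that. Also open, from the compounds shown here alone, is how a morpholine ring in this place, or a longer chain to the amine, would read.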